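This account rests on a few compounds, and the source may have more. Where it says the series, first, only, none or still open, it means among the compounds named here.

Of the compounds shown here, three with a shared core have been measured in an assay on DDT1 cells (Cricetulus griseus) for binding affinity to adenosine receptor A1 (Homo sapiens), read by radioligand binding; a higher number here means a weaker inhibitor, a lower number a stronger inhibitor. Compound 1 `C/N=C(\S)OC[C@H]1OC(n2cnc3c(NC4CCOC4)nc(Cl)nc32)[C@H](O)[C@@H]1O` gives 71 nM, compound 2 `CCCCNC(=O)OC[C@H]1OC(n2cnc3c(NC4CCOC4)ncnc32)[C@H](O)[C@@H]1O` gives 1410 nM, and compound 3 `CC(C)NC(=O)OC[C@H]1OC(n2cnc3c(NC4CCOC4)ncnc32)[C@H](O)[C@@H]1O` gives 78 nM. Compound 2 therefore has the highest number of the three: its nearest neighbour is compound 3, and compound 1 lies furthest from it, with both below it by amounts beyond the scatter. Going by the values given here, the one single-place step among the measured compounds is an 18-fold lower number from compound 2 to compound 3 (1.26 log units; beyond the scatter), that is, a smaller branched group on the same nitrogen instead of a straight butyl chain.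

Compound 4 `O[C@@H]1[C@@H](CO/C(S)=N/C2CCCC2)OC(n2cnc3c(NC4CCOC4)ncnc32)[C@@H]1O` is not yet measured. Compared with compound 2 it carries a group of 8 heavy atoms (6 carbon, 1 nitrogen, 1 sulfur; one five-membered non-aromatic ring of carbon only) in place of a group of 7 heavy atoms (5 carbon, 1 nitrogen, 1 oxygen; no ring), on an oxygen on a saturated carbon. Among the compounds with values here, only the step from compound 2 to compound 3 bears on this change, and it was large: trimming the butyl chain to a branched group lowered the number strongly. The group entering in compound 4 is again compact and ring-shaped rather than a straight chain, and compound 1, whose side chain shares the same sulfur-containing linkage with a small substituent, sits near compound 3. A large drop in this assay is therefore expected, with compound 4 estimated at 100 nM (range 30 nM to 400 nM), which means an expected step of a 14-fold lower number from compound 2 to compound 4 (1.15 log units; beyond the scatter).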

Compound 4, inhibition constant: 72 nM
For compound 4 the middle estimate is 1.4-fold (0.14 log units) above the measured one, within the range that was stated.
By their numbers in this assay, from the lowest: compounds 1, 4 and 3 (each within the scatter of the next); then compound 2.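

In this assay, swapping butylcarbamoyl on this oxygen for the sulfur-bearing group with its five-membered carbon ring gives a 20-fold lower number from compound 2 to compound 4 (1.29 log units; beyond the scatter), so a second, quite different group now matches the large change first seen with the isopropyl compound. The two replacement groups also end up indistinguishable, with a 1.1-fold lower number from compound 3 to compound 4 (0.03 log units; within the scatter), even though one has a ring and sulfur and the other has neither; at this position, then, the number tolerates a real change in the group, and among compounds 2, 3 and 4 only the butylcarbamoyl compound stands apart. Nothing shown here explains why these groups give the numbers they do.

Compound 4 changes the ring and the sulfur together, so the share of each in its step cannot be separated, and a cyclopentylcarbamoyl group, with the ring on the oxygen-containing linkage, or a butyl chain on the sulfur-containing linkage would be needed to pull them apart. How far the tolerance extends also stays open, since the compounds shown do not say whether a methyl, a hexyl chain or a phenyl ring on the same nitrogen would sit with compound 2 or with compounds 3 and 4.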